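Chloro to Methoxy Swap at Two Places on One Scaffold

The compounds below may be only part of what the source reports. "The series", "measured", "known", "first", "only" and "open" are said of these compounds alone.

Of the compounds shown here, three have been tested in a functional assay on PC-3 cells (Homo sapiens) for antiproliferative activity, read by MTT assay, with a stated time of 48 h (a higher number here means a weaker inhibitor, a lower number a stronger inhibitor), and a fourth awaits measurement. Compound 1 `O=C(/C=C\Nc1ccc(Cl)cc1)c1cn(-c2ccccc2)nc1-c1ccccc1` gives 5200 nM in this assay. Compound 2 `COc1ccc(N/C=C\C(=O)c2cn(-c3ccccc3)nc2-c2ccccc2)cc1` differs from compound 1 by methoxy in place of chloro on an aromatic carbon, and in this assay compound 2 gives 6400 nM. The step of a 1.2-fold higher number from compound 1 to compound 2 (0.09 log units; within the scatter) shows that this exchange left the activity essentially unchanged.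

Compound 3 `O=C(/C=C\Nc1ccc(F)cc1)c1cn(-c2ccccc2)nc1-c1ccc(Cl)cc1` carries a different set of substituents on the shared core; the difference between its core and that of compound 1 is not broken down here. In this assay compound 3 reaches only a limit of the assay, > 50000 nM, so no number is known for it (the limit of > 50000 nM in this assay, at which 1 of the 3 values shown sits).

Compound 4 `COc1ccc(-c2nn(-c3ccccc3)cc2C(=O)/C=C\Nc2ccc(F)cc2)cc1` is the unmeasured partner of compound 3, from which it differs by methoxy in place of chloro on an aromatic carbon. This is the same kind of change as that from compound 1 to compound 2, but not at the same place: for compound 1 to compound 2 the difference, cut one bond further out, also reads (4-chlorophenyl)amino to (4-methoxyphenyl)amino, whereas for compound 3 to compound 4 it reads only 4-chlorophenyl to 4-methoxyphenyl.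

Since the measured step of a 1.2-fold higher number from compound 1 to compound 2 (0.09 log units; within the scatter) stayed within the scatter, the expected step that the limit leaves unreadable from compound 3 to compound 4 is also small. Compound 4 is therefore expected at about 60000 nM, between 20000 nM and 200000 nM, and because compound 3 stands at > 50000 nM the assay may again report only a limit.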

Compound 4, half-maximal inhibitory concentration: 5730 nM
The estimate for compound 4 lay 10-fold (1.02 log units) above the measured number; measured number outside the range, below it.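

The exchange of 4-chlorophenyl for 4-methoxyphenyl gives a clear gain in this assay, with an at least 8.7-fold lower number from compound 3 to compound 4 (0.94 log units; beyond the scatter). The same kind of exchange therefore does not carry over as a fixed shift in this series, since its outcome here differs from the one seen at the other place on the shared core: the same change on two cores in this assay, a 1.2-fold higher number (0.09 log units; within the scatter) from compound 1 to compound 2 and an at least 8.7-fold lower number (0.94 log units; beyond the scatter) from compound 3 to compound 4, at least 10-fold (1.03 log units) apart, beyond the scatter of two such steps. Compound 3 stands only at a limit of the assay, > 50000 nM, so this step gives a minimum rather than a true size, and two pairs, with the exchange at a different place in each, show neither why the outcomes part nor what the exchange would do on any further core.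

The compounds shown leave open whether the fluoro carried by compound 3 and compound 4, absent from compound 1 and compound 2, has a share in the difference between the two steps, which a pair with the same exchange made at both places on one core could help to settle. Also open, on these data alone, is what a hydroxyl, an amine or a carboxylic acid would give in place of the methoxy of compound 4.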